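Aryl piperazine variation on the oxazole series: trifluoromethylphenyl analogue

The compounds below may be only part of what the source reports. "The series", "measured", "known", "first", "only" and "open" are said of these compounds alone.

Measured so far:
compound 1, `CCCc1nc(-c2ccccc2)c(CNCCN2CCN(c3ccc(F)cc3)CC2)o1`, 54.1%
compound 2, `CCCc1nc(-c2ccccc2)c(CNCCN2CCN(c3cccc(OC)c3)CC2)o1`, 40.2%

In an assay on HEK293 cells for inhibition of Voltage-dependent T-type calcium channel subunit alpha-1G (Homo sapiens), read by fluorescence, tested at 10 uM (on this read-out higher numbers stand for more inhibition at the one concentration tested (going by the name of the read-out) and lower numbers for less inhibition), compound 1 gives 54.1% and compound 2 gives 40.2%. Within the data shown here, compound 2 holds the lower of the two numbers; the only known step, a number 13.9 percentage points lower from compound 1 to compound 2 (beyond the scatter), is the one that leads to it.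

Compound 3, `CCCc1nc(-c2ccccc2)c(CNCCN2CCN(c3ccc(C(F)(F)F)cc3)CC2)o1`, is not yet measured. It differs from compound 2 by 4-(trifluoromethyl)phenyl in place of 3-methoxyphenyl on an amine nitrogen in a ring. Among the measured compounds shown here, the one step on record, a number 13.9 percentage points lower from compound 1 to compound 2 (beyond the scatter), also exchanges the aryl group on this ring nitrogen, so the change of aryl can move the read-out by a modest amount. Since compound 3 carries a substituent at the same position of the phenyl ring as compound 1, a move back toward the value of compound 1 is expected rather than a further fall.

Compound 3 is therefore expected to reach about 50%, with a range from 30% to 70%, an estimated step of a number 9.8 percentage points higher from compound 2 to compound 3 (within the scatter).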

Compound 3, a percentage reported as inhibition, at one concentration (the size of the read-out at that concentration, not a potency): 58.7%
Beside the measured number, compound 3's estimate is 8.7 percentage points below it; low and high end bracket the measured number.
By their numbers in this assay, from the lowest: compound 2; then compounds 1 and 3 (each within the scatter of the next).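

In this assay, 4-(trifluoromethyl)phenyl in place of 3-methoxyphenyl on the amine nitrogen in the ring gives a number 18.5 percentage points higher from compound 2 to compound 3 (beyond the scatter), so the lower number of compound 2 does not extend to every exchange of the aryl group at this position. Trifluoromethyl in place of fluoro on the aromatic carbon gives a number 4.6 percentage points higher from compound 1 to compound 3 (within the scatter), so compound 1 and compound 3 cannot be told apart on this read-out. Compound 2 differs from both in the substituent and in its place on the phenyl ring, and these two changes cannot yet be separated.

Nothing available explains the differences between these numbers. Open, on these data alone, is how 4-methoxyphenyl and 3-(trifluoromethyl)phenyl read on this nitrogen, which would separate group from ring place, and how a phenyl ring bearing a carboxylic acid reads there.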